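Chloro in place of fluoro on an aromatic carbon

The source may hold more compounds than are shown below. What is called first, only, known or untested is meant among the compounds shown, and "the series" means these compounds.

Measured in a functional assay on HepG2 cells (Homo sapiens) for inhibition, read by MTT assay; a lower number here means a stronger inhibitor, a higher number a weaker inhibitor:
Compound 1 `COc1cc2ncnc(Nc3ccc(NC(=O)c4ccc(C)cc4)cc3)c2cc1OC` gives 25000 nM
Compound 2 `COc1cc2ncnc(Nc3ccc(NC(=O)c4ccc(F)cc4)cc3)c2cc1OC` gives 15000 nM

Only these two compounds have been measured so far, so the picture is a narrow one. In this assay compound 2 stands at 15000 nM, which lies within the scatter of compound 1 at 25000 nM. Neither compound can be ranked above the other on these numbers.

The next compound, compound 3 `COc1cc2ncnc(Nc3ccc(NC(=O)c4ccc(Cl)cc4)cc3)c2cc1OC`, keeps the shared core and the amide and carries chloro in place of fluoro on an aromatic carbon, para to a large group (chloro in place of fluoro on an aromatic carbon). Within the data shown here, one measured step bears on this change: a 1.7-fold lower number from compound 1 to compound 2 (0.22 log units; within the scatter). That step altered the same substituent, fluoro in place of methyl on an aromatic carbon, and it stayed within the scatter. Among the measured compounds shown here, it is only a single step, so it offers thin support, but it gives no reason to look for a large shift at this place. The expected change is therefore none beyond the scatter, an estimated 1.2-fold higher number from compound 2 to compound 3 (0.08 log units; within the scatter). For compound 3 the estimated value is 18000 nM, with an expected range from 9000 nM to 35000 nM.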

Compound 3, half-maximal inhibitory concentration: 28000 nM
The estimate for compound 3 lay 1.6-fold (0.19 log units) below the measured number; the range from low to high includes it.
By their numbers in this assay, from the lowest: compounds 2, 1 and 3 (each within the scatter of the next).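

In this assay, the exchange of fluoro for chloro on this aromatic carbon gives a 1.9-fold higher number from compound 2 to compound 3 (0.27 log units; within the scatter), and the exchange of methyl for chloro gives a 1.1-fold higher number from compound 1 to compound 3 (0.05 log units; within the scatter). With methyl, fluoro and chloro now all tried at this one place, every step among the three lies within the scatter, so the earlier single step is joined by two more of the same kind, and this position has not yet separated any of these substituents from one another. No measured information bears on a cause for this result.

The compounds shown leave open whether a group of a different kind at this place, such as an amine, a carboxylic acid or a longer chain, would move the number beyond the scatter. From the compounds shown here alone, all three compounds also share the same core and the same amide, so it remains open whether a change in either of those parts would shift the number by more than the substituent exchanges seen here.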